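Piperazine substituent swap on a thiazolidinone antiproliferative scaffold

The source may hold more compounds than are shown below. What is called first, only, known or untested is meant among the compounds shown, and "the series" means these compounds.

Measured compounds:
Compound 1 `COC(=O)c1ccc(C2SCC(=O)N2c2ccc(N3CCN(Cc4cccc([N+](=O)[O-])c4)CC3)cn2)c(OC)c1`: 37400 nM
Compound 2 `COC(=O)c1ccc(C2SCC(=O)N2c2ccc(N3CCN(S(=O)(=O)c4ccccc4)CC3)cn2)c(OC)c1`: 52900 nM

Going by the values given here, in a functional assay on Jurkat cells (Homo sapiens) for antiproliferative activity, read by MTT assay and trypan blue exclusion, with a stated time of 72 h (a lower number here means a stronger inhibitor, a higher number a weaker inhibitor), compound 1 gives 37400 nM and compound 2 gives 52900 nM; the two numbers do not separate beyond the scatter, so compound 1 stands level with its only neighbour. Compound 3 `COC(=O)c1ccc(C2SCC(=O)N2c2ccc(N3CCN(S(=O)(=O)c4cc(Cl)ccc4Cl)CC3)cn2)c(OC)c1` differs from compound 1 by (2,5-dichlorophenyl)sulfonyl in place of 3-nitrobenzyl on an amine nitrogen in a ring. Among the compounds with values here, the one comparable step, a 1.4-fold higher number from compound 1 to compound 2 (0.15 log units; within the scatter), also exchanged the 3-nitrobenzyl for a sulfonyl group and stayed within the scatter. On that basis no change beyond the scatter is expected in this assay, so a 1.2-fold higher number from compound 1 to compound 3 (0.08 log units; within the scatter) is the estimated step. Compound 3 is therefore expected near 45000 nM, between 18000 nM and 110000 nM.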

Compound 3, half-maximal inhibitory concentration: > 100000 nM
Compound 3 ended at the assay's limit; the forecaster's own chance of this, stated with the estimate: 15%; middle value at least 2.2-fold (0.34 log units) away from the limit.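

In this assay, the value for compound 3 is a limit and not a number: the limit of > 100000 nM in this assay, at which 1 of the 3 values shown sits. Even so, the amine nitrogen in the ring proves sensitive to its substituent, with an at least 2.6-fold higher number from compound 1 to compound 3 (0.42 log units; beyond the scatter), a separation that the earlier phenylsulfonyl swap did not reach. The dichloro substitution alone is not resolved, since an at least 1.8-fold higher number from compound 2 to compound 3 (0.27 log units; that floor lies within the scatter).

Going by these compounds, the true value of compound 3 remains open. So does whether a single chlorine or a methoxy group on the phenylsulfonyl ring would separate from compound 2 in this assay.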